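Extending a phenyl to a styryl on the indole core

The compounds below may be only part of what the source reports. "The series", "measured", "known", "first", "only" and "open" are said of these compounds alone.

The series rests on the shared core of compound 1 `CC(=O)c1cc(-c2ccccc2)cc2cc(-c3ccccc3)[nH]c12`. In a functional assay on MCF7 cells (Homo sapiens) for cytotoxicity, read by MTT assay, with a stated time of 2 days, tested at 0.1 uM (a lower number here means a stronger effect, a higher number a weaker effect of the compound at the concentration tested), compound 1 gives 99.3%, the highest of the two numbers recorded; its nearest neighbour is compound 2 `COc1ccc(-c2cc3cc(-c4ccccc4)cc(C(C)=O)c3[nH]2)cc1`, which in this assay gives 87%. Among the compounds with values here, the one step recorded so far, a number 12.3 percentage points lower from compound 1 to compound 2 (beyond the scatter), comes from a methoxy in place of hydrogen on an aromatic carbon and is modest yet beyond the scatter. Compound 3 `CC(=O)c1cc(/C=C/c2ccccc2)cc2cc(-c3ccccc3)[nH]c12` is not yet measured and differs from compound 1 in one place: 2-phenylethenyl in place of phenyl on an aromatic carbon. Within the data shown here, no recorded step exchanges phenyl for 2-phenylethenyl, so the methoxy step is the only guide to how far a single change on this core can move the number, and that guide is indirect. A small downward shift is therefore the most that can be reasoned from what is shown. For compound 3 the estimate in this assay is 90%, within 74% to 100%, an expected step of a number 9.3 percentage points lower from compound 1 to compound 3 (within the scatter).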

Compound 3, a percentage reported as activity, at one concentration (the size of the read-out at that concentration, not a potency): 99.5%
Compound 3: middle estimate off by 9.5 percentage points, on the low side; the measured number falls inside the stated range.
By their numbers in this assay, from the lowest: compound 2; then compounds 1 and 3 (each within the scatter of the next).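

The exchange of phenyl for 2-phenylethenyl on this aromatic carbon, meta to an acetyl group, gives a number 0.2 percentage points higher from compound 1 to compound 3 (within the scatter) in this assay, so the read-out does not separate compound 1 from compound 3. This is the first step shown at this position, and it adds a double bond outside aromatic rings while the six-membered aromatic ring stays in the group; of the two steps shown, only a number 12.3 percentage points lower from compound 1 to compound 2 (beyond the scatter) lies beyond the scatter. The data shown offer no explanation for this result.

As far as these compounds go, whether an amine or a longer chain in place of the 2-phenylethenyl group would give a number apart from that of compound 1 remains open. Also open, from the compounds shown here alone, is whether a methoxy group would bring the same step on the core of compound 3 as it does on the core of compound 1.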